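Dropping the 2-cyanobenzyl group to a methyl

A few compounds are considered here, and "the series" means these few. Any claim that something is new, unique, unknown or untested is made for them only; others in the source may bear on it.

Compound 1, `N#Cc1ccccc1CN1c2ccsc2C(=O)N(Cc2ccccc2)S1(=O)=O`, is the starting point. In an ADME assay on MT4 cells (Homo sapiens) for cytotoxicity, read by MTT assay, with a stated time of 4 days (on this read-out higher numbers stand for lower toxicity in this test and lower numbers for higher toxicity in this test), compound 1 returns only a limit of the test, > 305000 nM, so its true value is not pinned down. Two neighbours differ from compound 1 at one place. Compound 2, `O=C1c2sccc2N(Cc2ccc(Br)cc2)S(=O)(=O)N1Cc1ccccc1`, gives 6600 nM in this assay. Compound 3, `N#CCN1c2ccsc2C(=O)N(Cc2ccccc2)S1(=O)=O`, gives 5700 nM in this assay. The step of an at least 46-fold lower number from compound 1 to compound 2 (1.66 log units; beyond the scatter) and the step of an at least 53-fold lower number from compound 1 to compound 3 (1.72 log units; beyond the scatter) both run toward more toxicity, and both rest on the limit of > 305000 nM in this assay, at which 1 of the 3 values shown sits, for compound 1, so their exact size is open. Between compound 2 and compound 3 the step of a 1.2-fold lower number from compound 2 to compound 3 (0.06 log units; within the scatter) shows no real difference.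

Compound 4, `CN1c2ccsc2C(=O)N(Cc2ccccc2)S1(=O)=O`, is not yet measured. It differs from compound 1 by hydrogen in place of 2-cyanophenyl on a saturated chain carbon bound to a sulfonamide nitrogen in a ring. Both measured steps away from the 2-cyanophenyl group gave much lower numbers, whether the replacement was a 4-bromophenyl or a cyano, so the same kind of move is expected here: a large step of an at least 33-fold lower number from compound 1 to compound 4 (1.53 log units; beyond the scatter) toward a lower number is expected for compound 4. The estimate for compound 4 in this assay is 9000 nM, with a range from 2500 nM to 60000 nM, expected to land near compound 2 and compound 3.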

Compound 4, half-maximal cytotoxic concentration: 202000 nM
Beside the measured number, compound 4's estimate is 22-fold (1.35 log units) below it, outside the stated range (above it).
By their numbers in this assay, from the lowest: compounds 3 and 2 (each within the scatter of the next); then compound 4. At a limit, above all of these: compound 1.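

In this assay hydrogen in place of cyano gives a 35-fold higher number from compound 3 to compound 4 (1.55 log units; beyond the scatter) and hydrogen in place of 4-bromophenyl gives a 31-fold higher number from compound 2 to compound 4 (1.49 log units; beyond the scatter) at this place on the chain. The earlier compounds shown here could suggest that any loss of the 2-cyanophenyl group brings a low number, but the methyl group of compound 4 goes against that reading, and the low numbers so far belong to compound 2 and compound 3, which carry a 4-bromophenyl or a cyano here. Compound 1 holds only a limit, so an at least 1.5-fold lower number from compound 1 to compound 4 (0.17 log units; that floor lies within the scatter) is no more than a floor, and whether the two truly differ in this test stays unsettled: the limit of > 305000 nM in this assay, at which 1 of the 4 values shown sits.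

The compounds shown leave open how a plain benzyl, a longer chain such as propyl, or a chain ending in an amine or a carboxylic acid would read at this place. They also leave open what a cyano and a 4-bromophenyl share that puts compound 2 and compound 3 within the scatter of each other, while the methyl group of compound 4 stands so far from both.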